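The source may hold more compounds than are shown below. What is called first, only, known or untested is meant among the compounds shown, and "the series" means these compounds.

Measured so far in a functional assay on PC-3 cells (Homo sapiens) for inhibition, read by sulforhodamine B assay, with a stated time of 72 h; a lower number here means a stronger inhibitor, a higher number a weaker inhibitor:
- compound 1 `Nc1sc(-c2ccc(Cl)cc2)c(-c2ccc(Cl)cc2)c1C(=O)NC1CCCCC1` gives 7300 nM
- compound 2 `CCCCNC(=O)c1c(N)sc(-c2ccc(Cl)cc2)c1-c1ccc(Cl)cc1` gives 17800 nM

Compound 2 has the higher number of the two, so it is the weaker inhibitor here. Compound 3 `Nc1sc(-c2ccc(Cl)cc2)c(-c2ccc(Cl)cc2)c1C(=O)N1CCCC1` has pyrrolidin-1-yl in place of butylamino on a carbonyl carbon. Going by the values given here, the only measured step bearing on this (a 2.4-fold higher number from compound 1 to compound 2 (0.39 log units; beyond the scatter)) is modest and exchanges butyl for cyclohexyl on an amide-type nitrogen. Among the compounds with values here, no measured compound lacks the amide hydrogen, so the guidance is loose. A small expected shift towards a lower number in this assay, probably within the scatter, is estimated (a 1.5-fold lower number from compound 2 to compound 3 (0.17 log units; within the scatter)). The estimate for compound 3 is 12000 nM (expected range 4500 nM to 35000 nM).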

Compound 3, half-maximal inhibitory concentration: 6220 nM
The estimate for compound 3 lay 1.9-fold (0.29 log units) above the measured number; low and high end bracket the measured number.
By their numbers in this assay, from the lowest: compounds 3 and 1 (each within the scatter of the next); then compound 2.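

In this assay, pyrrolidin-1-yl in place of butylamino on the carbonyl carbon gives a 2.9-fold lower number from compound 2 to compound 3 (0.46 log units; beyond the scatter) and so shows that this position accepts an amide without the amide hydrogen. Pyrrolidin-1-yl in place of cyclohexylamino gives a 1.2-fold lower number from compound 1 to compound 3 (0.07 log units; within the scatter) and leaves the two ring-bearing amides level, with the open-chain butylamino of compound 2 the weaker case. Nothing available explains these differences.

Diethylamino would test whether the ring or the missing amide hydrogen goes with the lower number. Morpholin-4-yl and piperidin-1-yl remain open as other ring choices at this carbonyl carbon.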